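Swapping the halogenated aryl group on compound 3

The compounds below may be only part of what the source reports. "The series", "measured", "known", "first", "only" and "open" are said of these compounds alone.

Measured compounds:
Compound 1, `CNC(=O)c1cc(Oc2ccc(NC(=O)c3cc4cccnc4n(-c4ccc(Br)cc4)c3=O)cc2)ccn1`, which in a functional assay on A549 cells (Homo sapiens) for antiproliferative activity, read by MTT assay, with a stated time of 72 h (on this read-out lower numbers stand for stronger inhibition and higher numbers for weaker inhibition), gives 1050 nM.
Compound 2, `CCNC(=O)c1cc(Oc2ccc(NC(=O)c3cc4cccnc4n(-c4ccccc4F)c3=O)cc2)ccn1`, which in this assay gives 490 nM.
Compound 3, `CCNC(=O)c1cc(Oc2ccc(NC(=O)c3cc4cccnc4n(-c4ccc(Br)cc4)c3=O)cc2)ccn1`, which in this assay gives 910 nM.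

Among these three numbers compound 3 stands second highest; its nearest neighbour is compound 1, and its furthest is compound 2, yet both gaps are within the scatter, so no order can be claimed. The two measured steps are equally modest: a 1.2-fold lower number from compound 1 to compound 3 (0.06 log units; within the scatter) and a 1.9-fold higher number from compound 2 to compound 3 (0.27 log units; within the scatter).

Compound 4, `CCNC(=O)c1cc(Oc2ccc(NC(=O)c3cc4cccnc4n(-c4ccc(F)c(Cl)c4)c3=O)cc2)ccn1`, has not yet been measured. It differs from compound 3 by 3-chloro-4-fluorophenyl in place of 4-bromophenyl on an aromatic nitrogen. The step from compound 2 to compound 3 is the one that bears on this change, since it also swaps the group on that aromatic nitrogen, and it stayed within the scatter. No step beyond the scatter is therefore expected in this assay, in either direction. Compound 4 is estimated to give 750 nM, with a range from 300 nM to 1900 nM. That estimate means an expected step of a 1.2-fold lower number from compound 3 to compound 4 (0.08 log units; within the scatter).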

Compound 4, half-maximal inhibitory concentration: 1920 nM
Estimate against measurement, compound 4: 2.6-fold (0.41 log units) below, and the stated range ends below it.
By their numbers in this assay, from the lowest: compounds 2, 3, 1 and 4 (each within the scatter of the next, the first and the last beyond it).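

The group on the aromatic nitrogen can move the result in this assay: the change to 3-chloro-4-fluorophenyl gives a 2.1-fold higher number from compound 3 to compound 4 (0.32 log units; beyond the scatter) and, starting from the 2-fluorophenyl group, a 3.9-fold higher number from compound 2 to compound 4 (0.59 log units; beyond the scatter). For the compounds shown here, the earlier swap at this nitrogen, between the 2-fluorophenyl and 4-bromophenyl groups, stayed within the scatter, so these are the first steps at this position to pass beyond it. Both are still modest, and both go towards weaker inhibition.

With both halogens changed together, the compounds shown cannot separate the part played by the chlorine from that of the fluorine, and a plain phenyl, a 3-chlorophenyl or a phenyl bearing an amine remains open at this position. Nothing here gives a measured reason for these steps.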